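A few compounds are considered here, and "the series" means these few. Any claim that something is new, unique, unknown or untested is made for them only; others in the source may bear on it.

Measured compounds:
compound 1, `CCCCC(C#CC(=O)OC)O/C=C/C(=O)OC`, 240 nM
compound 2, `CCOC(=O)C#CC(C[C@@H](C)CCC=C(C)C)O/C=C/C(=O)OCC`, 2600 nM
compound 3, `C#CCO/C=C/C(=O)OC`, > 100000 nM; this value is a limit of the assay, not a number

All three were tested in a functional assay on SW1573 cells (Homo sapiens) for antiproliferative activity, read by sulforhodamine B assay, with a stated time of 48 h; a higher number here means a weaker inhibitor of growth, a lower number a stronger inhibitor of growth. Of the two numbers shown, compound 1 gives the lower one; the value for compound 2 is higher by a gap well beyond the usual scatter. Compound 3 gives only (the limit of > 100000 nM in this assay, at which 1 of the 3 values shown sits), so no number for it can be compared.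

Compound 4, `COC(=O)C#CC(C)O/C=C/C(=O)OC`, is not yet measured. It differs from compound 1 in one place: hydrogen in place of propyl on a saturated chain carbon, two bonds along the chain from an oxygen on an unsaturated carbon and a triple-bonded carbon. The side chain on the saturated carbon is thus cut down to its smallest form while the rest of the molecule, including both ester groups and the triple bond, is kept unchanged.

Compound 1 and compound 2 show that a change in this chain can shift the result by more than the scatter. The step from compound 1 to compound 4 is expected to be a 6.3-fold higher number from compound 1 to compound 4 (0.80 log units; beyond the scatter), towards weaker inhibition of growth. Compound 4 is therefore estimated at 1500 nM, with a range from 300 nM to 8000 nM.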

Compound 4, concentration for 50% growth inhibition: 1700 nM
For compound 4 the middle estimate is 1.1-fold (0.05 log units) below the measured one, within the range that was stated.
By their numbers in this assay, from the lowest: compound 1; then compounds 4 and 2 (each within the scatter of the next). At a limit, above all of these: compound 3.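

In this assay, going by these compounds alone, the earlier compounds differed in several places, but this pair gives a direct reading of a single change: hydrogen in place of propyl on a saturated chain carbon, or butyl to methyl when cut one bond further out, gives a 7.1-fold higher number from compound 1 to compound 4 (0.85 log units; beyond the scatter). The longer chain of compound 1 therefore counts towards stronger inhibition of growth, yet it is not essential, since compound 4 with only methyl still gives a measured number of 1700 nM. Nothing measured here explains why this change weakens inhibition.

Going by these compounds, with only butyl and methyl compared at this position, it remains open how a propyl or hexyl chain, a cyclohexyl ring or an amine there would compare. On these data alone, the effect of replacing either ester with a carboxylic acid is also open.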